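This account rests on a few compounds, and the source may have more. Where it says the series, first, only, none or still open, it means among the compounds named here.

Measured compounds:
compound 1, `Cc1ccc(C2CC(=O)c3ccc(F)cc3O2)cc1`, 160 nM
compound 2, `Cc1ccc(C2CC(=O)c3ccc(C)cc3O2)cc1`, 500 nM
compound 3, `Cc1ccc([C@@H]2CC(=O)c3ccc(F)cc3O2)cc1`, 150 nM

All three were tested in an in vitro assay on BTI-TN-5B1-4 cells for inhibition of Amine oxidase [flavin-containing] B (Homo sapiens); a higher number here means a weaker inhibitor, a lower number a stronger inhibitor. Compound 2 gives 500 nM, and the change to compound 1, (fluoro in place of methyl on an aromatic carbon), brings a 3.1-fold lower number from compound 2 to compound 1 (0.49 log units; beyond the scatter). Compound 1 and compound 3 share every atom and bond and sit within the scatter of each other, a 1.1-fold lower number from compound 1 to compound 3 (0.03 log units; within the scatter); the only written difference between them is that one is drawn with a defined configuration and the other without, as noted by the fact that one of compounds 1 and 3 is drawn with a defined configuration and the other without, at the place where they differ. The difference between the cores of compound 2 and compound 3 is not broken down here.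

Compound 4, `O=C1C[C@@H](c2ccc(F)cc2)Oc2cc(F)ccc21`, is not yet measured in this assay. From compound 3 it differs by fluoro in place of methyl on an aromatic carbon. Within the data shown here, this is the same kind of change as the one from compound 2 to compound 1, but not the same: there the fluoro entered on a ring that is part of a fused or bridged system of two rings, meta to a fused ring and para to a fused ring, whereas here it enters on a six-membered aromatic ring of carbon only, para to a large group. Compound 3 gives 150 nM. The expected step in this assay from compound 3 to compound 4 is a 1.5-fold lower number from compound 3 to compound 4 (0.18 log units; within the scatter), resting on compound 2 to compound 1 having shown a 3.1-fold lower number from compound 2 to compound 1 (0.49 log units; beyond the scatter), tempered by the different ring on which the change falls. Compound 4 is therefore estimated at 100 nM, with a range from 40 nM to 300 nM.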

Compound 4, half-maximal inhibitory concentration: 170 nM
The estimate for compound 4 lay 1.7-fold (0.23 log units) below the measured number; measured number inside the range.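

In this assay, putting fluoro in place of methyl on the six-membered aromatic ring of carbon only, para to a large group, gives a 1.1-fold higher number from compound 3 to compound 4 (0.05 log units; within the scatter), so compound 3 and compound 4 cannot be told apart. The size of this swap therefore does not carry over from one core to the other in this series: the same change on two cores in this assay, a 3.1-fold lower number (0.49 log units; beyond the scatter) from compound 2 to compound 1 and a 1.1-fold higher number (0.05 log units; within the scatter) from compound 3 to compound 4, 3.5-fold (0.55 log units) apart, beyond the scatter of two such steps What the two steps do not show is why they differ, since the swap falls on a different ring in each pair and the rest of the molecule also differs, with fluoro already present on the other ring of compound 3 and methyl on the other ring of compound 2; two pairs also give no general rule for the series.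

The compounds shown leave open whether a compound with methyl on the fused ring system and fluoro on the other ring would separate these two explanations. They also leave open how other groups at the place of the swap, such as an amine, a carboxylic acid or a longer chain, would behave, and how the opposite configuration at the saturated ring carbon would compare with compound 3.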